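This account rests on a few compounds, and the source may have more. Where it says the series, first, only, none or still open, it means among the compounds named here.

Working notes on the series. In a functional assay (aorta) with Oryctolagus cuniculus as the target (on this read-out lower numbers stand for tighter binding and higher numbers for weaker binding), compound 3 `COc1ccccc1OCCCN1CCC(C(c2ccc(F)cc2)c2ccc(F)cc2)CC1` gives 2.51 nM, level with compound 1 `CCc1ccc(OCCCN2CCC(C(c3ccc(F)cc3)c3ccc(F)cc3)CC2)c(OC)c1` at 2.51 nM. Compound 2 `COc1cc(C#N)ccc1OCCCN1CCC(C(c2ccc(F)cc2)c2ccc(F)cc2)CC1` gives 2 nM, and all three numbers lie within the scatter of each other.

The next compound to read is compound 4 `Fc1ccc(C(c2ccc(F)cc2)C2CCN(CCCOc3ccccc3)CC2)cc1`, which carries hydrogen in place of methoxy on an aromatic carbon, ortho to a large group (hydrogen in place of methoxy on an aromatic carbon). The nearest evidence comes from three measured steps that exchange ethyl, cyano and hydrogen on an aromatic carbon: a 1.3-fold lower number from compound 1 to compound 2 (0.10 log units; within the scatter), no change at the digits printed from compound 1 to compound 3 (within the scatter) and a 1.3-fold higher number from compound 2 to compound 3 (0.10 log units; within the scatter). All three stay within the scatter, so this position tolerates exchange in the compounds measured. Among the measured compounds shown here, none of them touches the methoxy group, however, and no measured compound lacks it, so their bearing on the new step is indirect.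

Only a small step is expected in this assay, with a slight lean towards a higher number. The expected size is a 1.4-fold higher number from compound 3 to compound 4 (0.14 log units; within the scatter). For compound 4 the estimated value is 3.5 nM, with an expected range of 1.2 nM to 10 nM.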

Compound 4, dissociation constant: 1.59 nM
Compound 4: the middle estimate sits 2.2-fold (0.34 log units) above what was measured; the measured number falls inside the stated range.
By their numbers in this assay, from the lowest: compounds 4, 2, 1 and 3 (each within the scatter of the next).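

In this assay, among the compounds shown here, the first compound without the methoxy group shows that this group can go without the number leaving the scatter: hydrogen in its place gives a 1.6-fold lower number from compound 3 to compound 4 (0.20 log units; within the scatter) and thus keeps compound 4 level with compound 3. Removing the rest of the substitution at the same time reads alike, with a 1.3-fold lower number from compound 2 to compound 4 (0.10 log units; within the scatter) and a 1.6-fold lower number from compound 1 to compound 4 (0.20 log units; within the scatter) as the steps, so a plain phenoxy end serves as well as 4-cyano-2-methoxyphenoxy or 4-ethyl-2-methoxyphenoxy on the shared core. Nothing shown accounts for this tolerance.

Open, on these data alone, is how this place responds to groups other than methoxy and hydrogen, such as a hydroxyl, an amine or a carboxylic acid. Also open, as far as these compounds go, is whether ethyl and cyano read the same on a ring that lacks the methoxy group.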